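Nitrile in place of trifluoromethyl in the series of compound 1

The compounds below may be only part of what the source reports. "The series", "measured", "known", "first", "only" and "open" are said of these compounds alone.

Measured so far:
compound 1 `Cc1nn(-c2nc(-c3ccc(Cl)c(Cl)c3)c(SC(C)C)s2)c(C(=O)O)c1-c1cc(C(F)(F)F)cc(C(F)(F)F)c1` — 1800 nM
compound 2 `Cc1oncc1-c1nc(-n2nc(C(=O)O)c(-c3cc(Cl)cc(Cl)c3)c2C)sc1SC(C)C` — > 44000 nM

In a functional assay on BJAB cells (Homo sapiens) for antiproliferative activity, with a stated time of 4 days (on this read-out higher numbers stand for an effect only at larger amounts of compound and lower numbers for an effect already at smaller amounts), compound 1 gives 1800 nM. For compound 2 the read-out is a limit of the assay, > 44000 nM, not a number. For the measured compounds named here, compound 1 thus stands as the only compound with a numbered value in this assay; the other entry sits at the limit (the limit of > 44000 nM in this assay, at which 1 of the 2 values shown sits). Going by the values given here, no pair of measured compounds differs in one place, so no measured step is available to guide the next change.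

Compound 3 `Cc1nn(-c2nc(-c3ccc(Cl)c(Cl)c3)c(SC(C)C)s2)c(C(=O)O)c1-c1cc(C#N)cc(C(F)(F)F)c1` is not yet measured. It differs from compound 1 by cyano in place of trifluoromethyl on an aromatic carbon.

Among the compounds with values here, with no measured step to lean on, the expected step of a 1.4-fold higher number from compound 1 to compound 3 (0.14 log units; within the scatter) in this assay is small, toward a weaker effect, and not clearly beyond the scatter. Compound 3 is expected to give 2500 nM, with a range from 800 nM to 9000 nM.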

Compound 3, half-maximal effective concentration: 3600 nM
Beside the measured number, compound 3's estimate is 1.4-fold (0.16 log units) below it; measured number inside the range.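

In this assay, this aromatic carbon now has a measured single-place change, which reads a 2.0-fold higher number from compound 1 to compound 3 (0.30 log units; within the scatter). Cyano in place of trifluoromethyl, with the second trifluoromethyl group left in place, therefore keeps compound 3 within the scatter of compound 1, and this read-out does not separate the two groups at this position. No measurement shown here accounts for this step or for its size.

From the compounds shown here alone, it remains open whether this position would accept a different kind of group, such as an amine, a methoxy group or a primary amide, and whether the second trifluoromethyl group could also be exchanged. For the compounds shown here, for compound 2 the entry in this assay is a limit of the assay, > 44000 nM, and not a number, so it gives no measured step for the series.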